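This account rests on a few compounds, and the source may have more. Where it says the series, first, only, none or still open, it means among the compounds named here.

Measured so far in an assay on Prostate gland for inhibition of steroid 5-alpha-reductase (Rattus norvegicus); a higher number here means a weaker inhibitor, a lower number a stronger inhibitor:

compound 1 `CCC(C)n1ccc2cc(/C(C)=C/C(=O)Nc3ccccc3OCCCC(=O)O)ccc21` – 67 nM
compound 2 `CCCC(CC)n1ccc2cc(/C(C)=C/C(=O)Nc3ccccc3OCCCC(=O)O)ccc21` – 9.3 nM
compound 3 `CCCC(c1ccccc1)n1ccc2cc(/C(C)=C/C(=O)Nc3ccccc3OCCCC(=O)O)ccc21` – 9.1 nM

All three share the same core and differ only in the group on the aromatic nitrogen. Compound 3 gives the lowest number of the three in this assay, but its distance to compound 2 is within the scatter, so the two cannot be ranked against each other; only compound 1 stands clearly apart, with a number higher than both.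

Compound 4 `CCCCCC(c1ccccc1)n1ccc2cc(/C(C)=C/C(=O)Nc3ccccc3OCCCC(=O)O)ccc21` is the next step. Compared with compound 3 the change is ethyl in place of hydrogen on a saturated chain carbon, four bonds along the chain from an aromatic carbon and an aromatic nitrogen, so the propyl chain at that carbon becomes a pentyl chain.

Two measured steps speak to this. Going from compound 1 to compound 2 also put an ethyl onto a chain carbon near the aromatic nitrogen, and it gave a 7.2-fold lower number from compound 1 to compound 2 (0.86 log units; beyond the scatter). Going from compound 2 to compound 3, a larger group again, gave only a 1.0-fold lower number from compound 2 to compound 3 (0.01 log units; within the scatter), which is within the scatter. Enlarging this group thus helped once and then levelled off. A step of a 1.3-fold lower number from compound 3 to compound 4 (0.11 log units; within the scatter) is therefore expected, at most a small improvement or none beyond the scatter. For compound 4 the estimate in this assay is 7 nM, within 3 nM to 20 nM.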

Compound 4, half-maximal inhibitory concentration: 25 nM
The estimate for compound 4 lay 3.6-fold (0.55 log units) below the measured number; the whole stated range lies below it.
By their numbers in this assay, from the lowest: compounds 3 and 2 (each within the scatter of the next); then compound 4; then compound 1.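

Adding the ethyl gave a 2.7-fold higher number from compound 3 to compound 4 (0.44 log units; beyond the scatter) in this assay, the first step shown in which enlarging the group on the aromatic nitrogen makes the inhibitor weaker, so more carbon at this position does not keep helping. Compound 4 also falls behind the similarly potent compound 2, with a 2.7-fold higher number from compound 2 to compound 4 (0.43 log units; beyond the scatter), yet it keeps part of the gain over the smaller sec-butyl group, with a 2.7-fold lower number from compound 1 to compound 4 (0.43 log units; beyond the scatter), so the best size found so far is neither the smallest nor the largest group shown. The effect of adding an ethyl near this nitrogen therefore has no fixed direction, and even its sign depends on the group that receives it: the same change on two cores in this assay, a 7.2-fold lower number (0.86 log units; beyond the scatter) from compound 1 to compound 2 and a 2.7-fold higher number (0.44 log units; beyond the scatter) from compound 3 to compound 4, 20-fold (1.30 log units) apart, beyond the scatter of two such steps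

The compounds shown leave open where along the chain the loss begins, since a butyl chain in place of the propyl of compound 3 could already raise the number or could leave it unchanged. They also leave open whether a longer chain such as heptyl would weaken inhibition further, and whether an amine or a hydroxyl group on the pentyl chain would change the result.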